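From ethoxy to trifluoromethyl on an aromatic carbon

The compounds below may be only part of what the source reports. "The series", "measured", "known", "first", "only" and "open" are said of these compounds alone.

Of the compounds shown here, two have been measured in a functional assay on HeLa cells (Homo sapiens) for inhibition, read by sulforhodamine B assay (a lower number here means a stronger inhibitor, a higher number a weaker inhibitor), so far.

Compound 1 `COc1ccccc1NC1=CC(=O)c2nc3n(c2C1=O)[C@H]1OC[C@@H](O)[C@H]1OC3` gives 2950 nM
Compound 2 `CCOc1ccc(NC2=CC(=O)c3nc4n(c3C2=O)[C@H]2OC[C@@H](O)[C@H]2OC4)cc1` gives 3110 nM

Compound 2, at 3110 nM, stands within the scatter of compound 1, so neither can be ranked above the other. The next compound, compound 3 `O=C1C=C(Nc2ccc(C(F)(F)F)cc2)C(=O)c2c1nc1n2[C@H]2OC[C@@H](O)[C@H]2OC1`, keeps the core of compound 2 and differs from it in one place: trifluoromethyl in place of ethoxy on an aromatic carbon. Put simply, trifluoromethyl stands in place of ethoxy on an aromatic carbon, para to a large group.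

Going by the values given here, only one measured step bears on this change: a 1.1-fold higher number from compound 1 to compound 2 (0.02 log units; within the scatter). That step also alters the aromatic group on the amine nitrogen, and it stays within the scatter. It offers no reason to expect a shift in either direction, so no step beyond the scatter is anticipated in this assay. Among the compounds with values here, still, no measured compound carries trifluoromethyl, and one step is thin evidence, so the range is kept wide. The expected step is a 1.0-fold lower number from compound 2 to compound 3 (0.02 log units; within the scatter). For compound 3 the estimated value is 3000 nM, with an expected range from 1200 nM to 7500 nM.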

Compound 3, half-maximal inhibitory concentration: > 8000 nM
Compound 3: only a limit was reported (the forecaster's own chance of this, stated with the estimate: 5%); at least 2.6-fold (0.42 log units) between middle value and limit.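

In this assay compound 3 gives > 8000 nM, which is a limit of the assay and not a number: the limit of > 8000 nM in this assay, at which 1 of the 3 values shown sits. Even so, the change can be read in one direction: trifluoromethyl in place of ethoxy gives an at least 2.5-fold higher number from compound 2 to compound 3 (0.41 log units; beyond the scatter), and the comparison with the 2-methoxyphenyl group gives an at least 2.7-fold higher number from compound 1 to compound 3 (0.43 log units; beyond the scatter). The earlier pair had shown only a 1.1-fold higher number from compound 1 to compound 2 (0.02 log units; within the scatter), so the aromatic group on the amine nitrogen had seemed to make no measurable difference, whereas these compounds show that the outcome in this assay does depend on that group and that 4-(trifluoromethyl)phenyl on the shared core gives a weaker inhibitor than either of the two ether-bearing groups.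

As far as these compounds go, how much weaker compound 3 is remains unknown, since only the smallest possible size of each step can be read. The compounds shown also cannot separate the effect of losing ethoxy from that of gaining trifluoromethyl, and how a plain methyl, an amine or a carboxylic acid on the same aromatic carbon would read stays open.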